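The source may report more compounds than this note shows. Statements on the series, on what has been measured and on what is new or still open speak of the compounds shown alone.

Measured compounds:
- Compound 1, `CO/N=C/C=C/c1ccccc1OC(=O)c1ccccc1`, in a functional assay on HEK239 cells (Homo sapiens) for inhibition, read by ELISA, with a stated time of 24 h (a lower number here means a stronger inhibitor of growth, a higher number a weaker inhibitor of growth), gives > 100000 nM, which is a limit of the assay.
- Compound 2, `CC(=O)ONC(=O)/C=C/c1ccccc1OC(=O)c1ccccc1`, gives 18600 nM.

Among the measured compounds shown here, compound 2 is thus the only compound for which this assay returns a number; compound 1 sits at the limit of > 100000 nM in this assay, at which 1 of the 2 values shown sits. For the measured compounds named here, the one measured step, from compound 1 to compound 2, is an at least 5.3-fold lower number from compound 1 to compound 2 (0.73 log units; beyond the scatter), and it replaces one chain group with another on the double-bonded chain carbon. Compound 3, `O=C(/C=C/c1ccccc1OC(=O)c1ccccc1)NOC(=O)c1ccccc1`, differs from compound 2 in a different place: phenyl in place of methyl on a carbonyl carbon, that is, acetyl to benzoyl, or acetoxy to benzoyloxy. Going by the values given here, no measured step touches this carbonyl carbon, so the step from compound 1 to compound 2 does not bear on the change, and there is no basis for expecting movement in either direction. The expectation for compound 3 is therefore a step of a 1.2-fold lower number from compound 2 to compound 3 (0.07 log units; within the scatter), not beyond the scatter. Compound 3 is estimated at 16000 nM, within a range from 5000 nM to 50000 nM.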

Compound 3, concentration for 50% growth inhibition: 3200 nM
Beside the measured number, compound 3's estimate is 5.0-fold (0.70 log units) above it, outside the stated range (below it).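

In this assay, the carbonyl carbon whose other neighbour is the oxygen next to a carbonyl group turns out to be sensitive to the group it carries: phenyl in place of methyl gives a 5.8-fold lower number from compound 2 to compound 3 (0.76 log units; beyond the scatter). Among the compounds shown here, the one earlier step exchanged a whole chain group on the double-bonded chain carbon, whereas this one leaves everything else in place, so it shows that the far end of the acyl group alone can move the number and that a six-membered aromatic ring is accepted there without any loss of growth inhibition. Nothing given here accounts for the size or direction of this step.

Whether the ring itself matters or only the larger group remains open, as the compounds shown include no cyclohexyl group, longer alkyl chain or chlorophenyl ring on this carbonyl carbon to separate the two readings. From the compounds shown here alone, the change also rests on a single pair of compounds, so it is unknown whether it would carry over to another core or how either compound compares with the free hydroxamic acid.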